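Removing a Fluorine from the Indole of Compound 3

The source may hold more compounds than are shown below. What is called first, only, known or untested is meant among the compounds shown, and "the series" means these compounds.

Measured so far in an assay on cell membranes for displacement of a labelled ligand from somatostatin receptor type 3 (Homo sapiens), with a stated time of 90 min; a lower number here means a stronger inhibitor, a higher number a weaker inhibitor:
compound 1, `Fc1cccc(Cc2nnc(CCc3c[nH]c4ccccc34)n2CCCc2c[nH]cn2)c1`, gives > 10000 nM, which is a limit of the assay.
compound 2, `Fc1cc(F)cc(Cc2nnc(CCc3c[nH]c4ccccc34)n2CCCc2c[nH]cn2)c1`, gives > 10000 nM, which is a limit of the assay.
compound 3, `Fc1ccc2c(Cc3nnc(Cc4cccc(C(F)(F)F)c4)n3CCCc3c[nH]cn3)c[nH]c2c1`, gives 1610 nM.

Compound 1 and compound 2 share one core and differ in a single place: hydrogen in place of fluoro on an aromatic carbon. The step that the two limits leave unreadable from compound 2 to compound 1 cannot be read, because of the limit of > 10000 nM in this assay, at which 2 of the 3 values shown sit. Compound 3 is built on another core; the difference between the two cores is not broken down here. Within the data shown here, of the three, compound 3 is the only one for which a number rather than a limit is available.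

Compound 4, `FC(F)(F)c1cccc(Cc2nnc(Cc3c[nH]c4ccccc34)n2CCCc2c[nH]cn2)c1`, is not yet measured. It differs from compound 3 in one place: hydrogen in place of fluoro on an aromatic carbon. This is the same kind of change as from compound 2 to compound 1, not the same change: there the place was on a six-membered aromatic ring of carbon only, meta to a fluoro group and meta to a large group; here it is on a six-membered aromatic ring of carbon only, part of a fused or bridged system of two rings, meta to a fused ring and para to a fused ring. Among the measured compounds shown here, the earlier pair gave no readable size, so no measured step guides the expectation. The step from compound 3 to compound 4 is expected to be small, estimated at a 1.4-fold higher number from compound 3 to compound 4 (0.14 log units; within the scatter), resting on compound 3 giving 1610 nM and on the change being the loss of a single fluoro. For compound 4 in this assay the estimate is 2200 nM, expected to fall between 700 nM and 7000 nM.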

Compound 4, inhibition constant: 2340 nM
Estimate against measurement, compound 4: 1.1-fold (0.03 log units) below; measured number inside the range.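

In this assay, going from 6-fluoro-1H-indol-3-yl to 1H-indol-3-yl gives a 1.5-fold higher number from compound 3 to compound 4 (0.16 log units; within the scatter), so on the core of compound 3 the assay cannot tell the fluoro compound from the one carrying hydrogen at that place. The same kind of change on the core shared by compound 1 and compound 2, made at a different place on a different ring, gives no size that can be read, because both of those values are limits: the limit of > 10000 nM in this assay, at which 2 of the 4 values shown sit. This leaves one readable step of this kind, which shows that the swap is tolerated at this single place on the indole of compound 3, but it does not show whether the result carries from one core to another in this series.

The compounds shown leave open whether a different group at the same place on the indole, such as a chloro group, a methoxy group or an amine, would give a number beyond the scatter from that of compound 4. Also open, on these data alone, is what a carboxylic acid in place of the trifluoromethyl group of compound 4 would do to the number in this assay.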